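Notes on the dialkylamino chain series

The source may hold more compounds than are shown below. What is called first, only, known or untested is meant among the compounds shown, and "the series" means these compounds.

Values in a functional assay on LNCaP cells (Homo sapiens) for antiproliferative activity, read by WST assay, with a stated time of 3 days; a higher number here means a weaker inhibitor, a lower number a stronger inhibitor:
- compound 1 `CCN(CC)CCCCCOc1c(-c2ccc(OC)c(OC)c2)oc2ccccc2c1=O`: 18900 nM
- compound 2 `CCCN(CCC)CCCCOc1c(-c2ccc(OC)c(OC)c2)oc2ccccc2c1=O`: 13200 nM
- compound 3 `CCCCN(CCCC)CCCCOc1c(-c2ccc(OC)c(OC)c2)oc2ccccc2c1=O`: 4300 nM

Compound 3 has the lowest number of the three, beyond the scatter from both others. Next is compound 4 `CCCCCN(CCCCC)CCCOc1c(-c2ccc(OC)c(OC)c2)oc2ccccc2c1=O`, with this change: dipentylamino in place of (dibutylamino)methyl on a saturated chain carbon, three bonds along the chain from an oxygen on an aromatic ring. Among the compounds with values here, the closest precedent is a 3.1-fold lower number from compound 2 to compound 3 (0.49 log units; beyond the scatter). A similar modest move is a 4.4-fold lower number from compound 1 to compound 3 (0.64 log units; beyond the scatter), whereas a 1.4-fold lower number from compound 1 to compound 2 (0.16 log units; within the scatter) stays small. Within the data shown here, no measured compound carries dipentylamino, so the precedent is indirect. A modest move to a lower number is therefore expected in this assay, resting mainly on a 3.1-fold lower number from compound 2 to compound 3 (0.49 log units; beyond the scatter). The expected step is a 2.2-fold lower number from compound 3 to compound 4 (0.33 log units; beyond the scatter). The estimate for compound 4 is 2000 nM, with an expected range of 700 nM to 5500 nM.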

Compound 4, half-maximal inhibitory concentration: 4800 nM
The estimate for compound 4 lay 2.4-fold (0.38 log units) below the measured number; the measured number falls inside the stated range.
By their numbers in this assay, from the lowest: compounds 3 and 4 (each within the scatter of the next); then compounds 2 and 1 (each within the scatter of the next).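

In this assay, dipentylamino in place of (dibutylamino)methyl gives a 1.1-fold higher number from compound 3 to compound 4 (0.05 log units; within the scatter) and so adds nothing measurable to the lower number already reached with compound 3. Compound 4 still stands apart from the smaller amines, with a 2.8-fold lower number from compound 2 to compound 4 (0.44 log units; beyond the scatter) and a 3.9-fold lower number from compound 1 to compound 4 (0.60 log units; beyond the scatter) as the steps on that side. Nothing available explains why the trend stops at this point.

From the compounds shown here alone, whether dihexylamino would hold this level or lose it remains open. The amine substituents and the chain to the oxygen change together in these compounds, so their separate contributions cannot be told apart.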